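Removing one chloro from compound 3

A few compounds are considered here, and "the series" means these few. Any claim that something is new, unique, unknown or untested is made for them only; others in the source may bear on it.

Compound 1 (`C/N=C(\S)[C@]1(c2ccccn2)CCCC[S+]1[O-]`) gives > 30000 nM (a limit of the assay)
Compound 2 (`C/N=C(\S)[C@]1(c2cnc3ccccc3c2)CCCC[S+]1[O-]`) gives 60 nM
Compound 3 (`C/N=C(\S)[C@]1(c2ccc(Cl)c(Cl)c2)CCCC[S+]1[O-]`) gives 300 nM

These results come from a functional assay (aorta) for inhibition, with Rattus norvegicus as the target; a lower number here means a stronger inhibitor, a higher number a weaker inhibitor. Of the two actual numbers, compound 3 (300 nM) holds the higher, and the gap down to compound 2 (60 nM) lies beyond the scatter. Compound 4 (`C/N=C(\S)[C@]1(c2ccc(Cl)cc2)CCCC[S+]1[O-]`) has hydrogen in place of chloro on an aromatic carbon of compound 3, ortho to a chloro group (hydrogen in place of chloro on an aromatic carbon). Going by the values given here, no measured pair shows this change on its own, so the expectation in this assay is only a judgement: a moderate move to a higher number, beyond the scatter. The expected size is a 3.3-fold higher number from compound 3 to compound 4 (0.52 log units; beyond the scatter). For compound 4 the estimated value is 1000 nM, with an expected range of 200 nM to 6000 nM.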

Compound 4, concentration for 90% inhibition: 2800 nM
For compound 4 the middle estimate is 2.8-fold (0.45 log units) below the measured one, and the stated range covers the measured number.
By their numbers in this assay, from the lowest: compound 2; then compound 3; then compound 4. At a limit, above all of these: compound 1.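

In this assay, hydrogen in place of chloro on this aromatic carbon, ortho to a chloro group and meta to a large group, gives a 9.3-fold higher number from compound 3 to compound 4 (0.97 log units; beyond the scatter), so this single chloro carries real weight. The earlier compounds shown here offered no comparison that isolated one change. Only compound 1 stands at a limit, and neither compound of this step does: the limit of > 30000 nM in this assay, at which 1 of the 4 values shown sits.

As far as these compounds go, whether a fluoro, a methyl or a methoxy group at this position would match the chloro remains open. So does the contribution of the remaining chloro group of compound 4.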